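The compounds below may be only part of what the source reports. "The series", "measured", "known", "first", "only" and "open" are said of these compounds alone.

Measured compounds:
- compound 1, `CC(C)C(=O)N1C[C@@H](O[C@H](C)c2cc(C(F)(F)F)cc(C(F)(F)F)c2)[C@H](c2ccc(F)cc2)C1`, in an assay on CHO cells for displacement of a labelled ligand from Substance-P receptor (Homo sapiens) (a higher number here means a weaker inhibitor, a lower number a stronger inhibitor), compound 1 gives 0.15 nM
- compound 2, `C[C@@H](O[C@@H]1CN(C(=O)N(C)C)C[C@H]1c1ccc(F)cc1)c1cc(C(F)(F)F)cc(C(F)(F)F)c1`, in this assay compound 2 gives 0.38 nM

Of the two numbers shown, compound 2 has the higher one: going a 2.5-fold higher number from compound 1 to compound 2 (0.40 log units; beyond the scatter), so compound 2 is the weaker of the pair, and the gap is beyond the scatter. Compound 3, `C[C@@H](O[C@@H]1CN(C(=O)NC(C)(C)C)C[C@H]1c1ccc(F)cc1)c1cc(C(F)(F)F)cc(C(F)(F)F)c1`, is not yet measured. It differs from compound 2 in one place: (tert-butyl)amino in place of dimethylamino on a carbonyl carbon. For the measured compounds named here, only one measured step exists, and it swaps an isopropyl for a dimethylamino on the same carbonyl carbon; it does not test what happens when one of the two methyls on that nitrogen is removed and the other is replaced by a tert-butyl, nor what a hydrogen-bond donor there does. That step was modest in size, and with no closer guide, the change from compound 2 to compound 3 is expected to be of a similar or smaller size in this assay, leaning towards a somewhat higher number, though a result within the scatter is also plausible. For compound 3 the estimated value is 0.55 nM, with a range from 0.15 nM to 2 nM, which as a step is expected to read a 1.4-fold higher number from compound 2 to compound 3 (0.16 log units; within the scatter).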

Compound 3, half-maximal inhibitory concentration: 0.14 nM
For compound 3 the middle estimate is 3.9-fold (0.59 log units) above the measured one, and the stated range ends above it.
By their numbers in this assay, from the lowest: compounds 3 and 1 (each within the scatter of the next); then compound 2.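

On the carbonyl carbon whose other neighbour is the amide-type nitrogen in a ring, swapping dimethylamino for (tert-butyl)amino gives a 2.7-fold lower number from compound 2 to compound 3 (0.43 log units; beyond the scatter) in this assay, so the weakening seen with dimethylamino does not extend to every amino group at this place. Putting (tert-butyl)amino in place of isopropyl gives a 1.1-fold lower number from compound 1 to compound 3 (0.03 log units; within the scatter) and therefore no real change, which shows that an amino group here can read the same as the isopropyl group of compound 1. The two amino groups differ both in size and in the amide hydrogen that only (tert-butyl)amino carries, and nothing available separates these two differences or explains the step.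

The compounds shown leave open whether methylamino, which keeps the amide hydrogen with a much smaller carbon group, would read like dimethylamino or like (tert-butyl)amino. They also leave open how a ring amine such as pyrrolidine or morpholine, joined through its nitrogen to the same carbonyl carbon, would compare.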